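Terminal alkyne on the ether chain of compound 2

The source may report more compounds than this note shows. Statements on the series, on what has been measured and on what is new or still open speak of the compounds shown alone.

Among the compounds with values here, compound 2 `C=CCc1cc(C(C)=O)c(O)cc1OCCCCC` gives 23% in an assay on isolated protein for binding affinity to leukotriene B4 receptor 1 (Homo sapiens), tested at 1 uM (a higher number here means more inhibition at the concentration tested (going by the name of the read-out), a lower number less inhibition), the lowest of the two numbers measured so far. Compound 1 `C=CCc1cc(C(C)=O)c(O)cc1OCCCCCCC#N` gives 63% in this assay. Within the data shown here, the single measured step, a number 40 percentage points lower from compound 1 to compound 2 (beyond the scatter), is large. Compound 3 `C#CCCCCOc1cc(O)c(C(C)=O)cc1CC=C` carries ethynyl in place of methyl on a saturated chain carbon, four bonds along the chain from an oxygen on an aromatic ring. Among the measured compounds shown here, no measured step covers this change directly; the step from compound 1 to compound 2 is the nearest reference, though it concerns a different group on the same chain. A rise beyond the scatter is nevertheless expected, a number 17 percentage points higher from compound 2 to compound 3 (beyond the scatter). Compound 3 is estimated at 40%, with a range from 20% to 60%.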

Compound 3, a percentage reported as inhibition, at one concentration (the size of the read-out at that concentration, not a potency): 29%
Estimate against measurement, compound 3: 11 percentage points above; the measured number falls inside the stated range.
By their numbers in this assay, from the lowest: compounds 2 and 3 (each within the scatter of the next); then compound 1.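

In this assay, ethynyl in place of methyl at this chain position changes little, with a number 6 percentage points higher from compound 2 to compound 3 (within the scatter). Ethynyl does not match 2-cyanoethyl at the same position, with a number 34 percentage points lower from compound 1 to compound 3 (beyond the scatter), so a terminal triple bond on the chain is not enough here to reach the level seen with the longer nitrile-ended chain. Nothing on hand explains this gap between the two chain ends.

Still open is whether the nitrile-ended chain needs its full length, since a cyanomethyl group at this position is not among the compounds shown. From the compounds shown here alone, a carboxylic acid or an amine at the chain end also remains open.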